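The compounds below may be only part of what the source reports. "The series", "measured", "known", "first", "only" and "open" are said of these compounds alone.

Values in an ADME assay on microsomes (Mus musculus) for metabolic stability, with a stated time of 1 h, tested at 1 uM; on this read-out higher numbers stand for a more stable compound and lower numbers for a less stable compound:

- compound 1 `C[C@H](CO)N1C[C@H](C)[C@H](CN(C)Cc2ccc(Oc3ccccc3)cc2)Oc2c(NC(=O)c3ccncc3)cccc2C1=O`: < 1%, a limit
- compound 2 `C[C@@H]1CN([C@H](C)CO)C(=O)c2cccc(NC(=O)c3ccncc3)c2O[C@@H]1CN(C)Cc1ccc(Oc2ccccc2)cc1`: < 1%, a limit
- compound 3 `C[C@@H]1CN([C@H](C)CO)C(=O)c2cccc(NC(=O)c3ccncc3)c2O[C@H]1CN(C)Cc1ccc(Oc2ccccc2)cc1`: 1%

Among the compounds with values here, compound 3 carries the only actual number of the three. The other two sit at the limit of < 1% in this assay, at which 2 of the 3 values shown sit.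

Compound 4 `C[C@@H]1CN([C@@H](C)CO)C(=O)c2cccc(NC(=O)c3ccncc3)c2O[C@@H]1CN(C)Cc1ccc(Oc2ccccc2)cc1` is reached from compound 3 by the two compounds have the same atoms and bonds and differ only in configuration as drawn: 2 of 3 stereo elements differ; a stereocentre at a saturated chain carbon is drawn R in compound 3 and S in compound 4; a stereocentre at a saturated ring carbon is drawn R in compound 3 and S in compound 4.

Within the data shown here, the steps that bear on this are a step that the two limits leave unreadable from compound 1 to compound 2, a number no lower from compound 1 to compound 3 (the limit leaves the size open) and a number no lower from compound 2 to compound 3 (the limit leaves the size open). All three change ring-carbon configuration only, and none has a readable size. Among the measured compounds shown here, no measured step changes the chain carbon. Every configuration measured so far stays close to the bottom of the scale, so no rise is anticipated.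

The expected step is no change at the digits printed from compound 3 to compound 4 (within the scatter), with nothing expected beyond the scatter. For compound 4 the estimate is 1%, with an expected range of 0.3% to 6%.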

Compound 4, percent of the compound remaining: < 1%
Compound 4 ended at the assay's limit; the forecaster's own chance of this, stated with the estimate: 55%; the middle value lies on the limit itself.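

In this assay compound 4 gives < 1%, which is a limit of the assay. Within the data shown here, the chain carbon changes configuration for the first time here, giving a number no higher from compound 3 to compound 4 (the limit leaves the size open). The steps to compound 4 from compound 1, its mirror image, and from compound 2, which differs only at the chain carbon, cannot be read, so neither inversion shows a measurable gain: the limit of < 1% in this assay, at which 3 of the 4 values shown sit.

Any differences among the configurations that sit at the limit stay open. Also open, on these data alone, is whether a carboxylic acid or an amine on the shared core would give a readable number.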